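Adding ethyl to the side chain of compound 3

This account rests on a few compounds, and the source may have more. Where it says the series, first, only, none or still open, it means among the compounds named here.

In an ADME assay on L02 cells (Homo sapiens) for cytotoxicity, read by MTT assay, with a stated time of 72 h (a higher number here means a weaker inhibitor, a lower number a stronger inhibitor), compound 3 `C/C=C/C(=O)Nc1cccc(Oc2nc(Nc3cccc(C#N)c3)nc3c2CSCC3)c1` gives > 50000 nM as a limit of the assay and not a number. Compound 2 `C=CC(=O)Nc1cccc(Oc2nc(Nc3cccc(C#N)c3)nc3c2CSCC3)c1` gives > 50000 nM as a limit too. Compound 1 `CCC/C=C/C(=O)Nc1cccc(Oc2nc(Nc3cccc(OC)c3)nc3c2CSCC3)c1` already carries pent-1-en-1-yl and gives > 50000 nM as a limit too. All the evidence so far is the limit of > 50000 nM in this assay, at which 3 of the 3 values shown sit, and nothing finer. Compound 4 `CCC/C=C/C(=O)Nc1cccc(Oc2nc(Nc3cccc(C#N)c3)nc3c2CSCC3)c1` turns the prop-1-en-1-yl of compound 3 into pent-1-en-1-yl through ethyl in place of hydrogen on a saturated chain carbon bound to a double-bonded chain carbon and nothing else. For the measured compounds named here, the one measured step is a step that the two limits leave unreadable from compound 2 to compound 3 and offers no size to carry over. No shift beyond the scatter is expected, so a number no higher from compound 3 to compound 4 (the limit leaves the size open) is the expected outcome in this assay for this change. Compound 4 is estimated at 50000 nM with an expected range from 30000 nM to 90000 nM and will probably be reported as a limit again.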

Compound 4, half-maximal inhibitory concentration: > 50000 nM
Compound 4 gave a limit, no number; the forecaster's own chance of this, stated with the estimate: 85%; the middle value lies on the limit itself.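

For the compounds shown here, compound 1, compound 2, compound 3 and compound 4 all give only a limit in this assay, so no step among them can be read. The compounds shown leave open where their actual values lie and whether changing the side chain shifts them.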